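A few compounds are considered here, and "the series" means these few. Any claim that something is new, unique, unknown or untested is made for them only; others in the source may bear on it.

Read-outs in a functional assay on K562 cells (Homo sapiens) for inhibition, read by fluorescence, with a stated time of 72 h (on this read-out lower numbers stand for stronger inhibition of growth and higher numbers for weaker inhibition of growth), as follows:
compound 1 `CCCCCCn1cnc2c(Nc3ccc(Cl)cc3)nc(N[C@H]3CC[C@H](N)CC3)nc21` gives 2100 nM
compound 2 `COc1cc(Nc2nc(N[C@H]3CC[C@H](N)CC3)nc3c2ncn3CCC(C)C)cc(OC)c1` gives 2500 nM
compound 3 `CCCCCCn1cnc2c(Nc3cc(OC)cc(OC)c3)nc(N[C@H]3CC[C@H](N)CC3)nc21` gives 1900 nM

Compound 3 stands level with the other two numbers. The steps reaching it are small (a 1.1-fold lower number from compound 1 to compound 3 (0.04 log units; within the scatter); a 1.3-fold lower number from compound 2 to compound 3 (0.12 log units; within the scatter)) and neither leaves the scatter. Compound 4 `CCCCCCn1cnc2c(Nc3ccc(O)cc3)nc(N[C@H]3CC[C@H](N)CC3)nc21` differs from compound 3 in one place, with 4-hydroxyphenyl in place of 3,5-dimethoxyphenyl on a nitrogen on an aromatic ring. Within the data shown here, only one measured step lies at that nitrogen (a 1.1-fold lower number from compound 1 to compound 3 (0.04 log units; within the scatter)), and it sets the expectation. Among the measured compounds shown here, no measured compound carries 4-hydroxyphenyl, so the basis is thin. In this assay the expected step (a 1.1-fold higher number from compound 3 to compound 4 (0.02 log units; within the scatter)) is none beyond the scatter, in either direction. Compound 4 is estimated at 2000 nM with an expected range from 800 nM to 5000 nM on this read-out.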

Compound 4, concentration for 50% growth inhibition: 5400 nM
The estimate for compound 4 lay 2.7-fold (0.43 log units) below the measured number; the whole stated range lies below it.
By their numbers in this assay, from the lowest: compounds 3, 1 and 2 (each within the scatter of the next); then compound 4.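

In this assay the group on this nitrogen is not indifferent: 4-hydroxyphenyl in place of 3,5-dimethoxyphenyl gives a 2.8-fold higher number from compound 3 to compound 4 (0.45 log units; beyond the scatter) and hydroxy in place of chloro gives a 2.6-fold higher number from compound 1 to compound 4 (0.41 log units; beyond the scatter). Among these compounds, the earlier exchange at this nitrogen stayed within the scatter, so 4-hydroxyphenyl is the first group here to move the number beyond it, and upward. Nothing available bears on the reason for this.

Going by these compounds, whether a methoxy or an amine in place of the hydroxy would read like compound 4 or like compound 1 remains open.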